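Second chloro on the core of compound 1: expected cytotoxicity

The source may report more compounds than this note shows. Statements on the series, on what has been measured and on what is new or still open speak of the compounds shown alone.

Compound 1 `ClCc1ccc(Cn2cnc3c(Cl)ncnc32)cc1` is the reference point of this short set. In a functional assay on UO-31 cells (Homo sapiens) for cytotoxicity, read by sulforhodamine B assay, with a stated time of 48 h (a lower number here means that less compound is tolerated, a higher number that more compound is tolerated), compound 1 reaches only the limit of the assay, > 100000 nM. Among the measured compounds shown here, compound 1 therefore stands at the edge of what the numbers can show, as recorded in the limit of > 100000 nM in this assay, at which 1 of the 3 values shown sits, and no step from it to another measured compound is available. Two further compounds belong to the set. Compound 2 `ClCc1cccc(Cn2cnc3nc(Cl)nc(Cl)c32)c1` gives 72400 nM in this assay. Compound 3 `ClCc1ccccc1Cn1cnc2nc(Cl)nc(Cl)c21` has "not determined" (no result reported) in this assay, so it contributes no number. Compound 4 `ClCc1ccc(Cn2cnc3c(Cl)nc(Cl)nc32)cc1` has not yet been measured. It differs from compound 1 by chloro in place of hydrogen on an aromatic carbon. For the measured compounds named here, no measured step reports the effect of this change. Compound 2, which already bears the entering chloro group on its core and gives 72400 nM, is the closest guide, and its value also lies in the high region of this assay. Only a small step from compound 1 is expected, if any beyond the scatter, in the direction of less compound tolerated. Compound 4 is expected to give 80000 nM in this assay, within a range from 30000 nM to 200000 nM. That estimate means a step of an at least 1.2-fold lower number from compound 1 to compound 4 (0.09 log units; that floor lies within the scatter) that is expected to stay close to the limit.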

Compound 4, concentration lethal to 50% of the cells: 66100 nM
The estimate for compound 4 lay 1.2-fold (0.08 log units) above the measured number; the measured number falls inside the stated range.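

Among the compounds shown here, for the first time, a single change can be read as a step in this assay: chloro in place of hydrogen on an aromatic carbon, between two ring nitrogen atoms, gives an at least 1.5-fold lower number from compound 1 to compound 4 (0.17 log units; that floor lies within the scatter) and places a measured number at the end of that step. For compound 1, the entry > 100000 nM is a limit of the assay and not a number. The size of the step remains only a floor, because one of its ends rests on that limit, and this floor alone does not establish a change beyond the scatter: the limit of > 100000 nM in this assay, at which 1 of the 4 values shown sits.

The compounds shown leave open how large the effect of this chloro group really is, and whether a step beyond the scatter would appear if the reference compound had a single number. Also open, going by these compounds, is how this carbon would respond to an amine or a methoxy group in place of chloro, since the only substitution here that can be read as a step is chloro in place of hydrogen.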